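A Third Methoxy on the Pendant Phenyl of Compound 2

The source may hold more compounds than are shown below. What is called first, only, known or untested is meant among the compounds shown, and "the series" means these compounds.

Among the measured compounds shown here, in a functional assay on ACHN cells (Homo sapiens) for cytotoxicity, read by MTT assay, with a stated time of 48 h (on this read-out higher numbers stand for weaker inhibition and lower numbers for stronger inhibition), compound 2 `COc1ccc(-c2cc(C(=O)Nc3nc4ccc(F)cc4s3)nc3cc(-c4ccccc4)nn23)cc1OC` gives 8120 nM, the lowest of the two numbers measured so far. For the measured compounds named here, its only neighbour is compound 1 `COc1ccc(-c2cc(C(=O)Nc3nc4ccc(F)cc4s3)nc3cc(-c4ccccc4)nn23)cc1`, which gives 39300 nM in this assay; the step of a 4.8-fold lower number from compound 1 to compound 2 (0.68 log units; beyond the scatter) separates them. Compound 3 `COc1cc(-c2cc(C(=O)Nc3nc4ccc(F)cc4s3)nc3cc(-c4ccccc4)nn23)cc(OC)c1OC` has not yet been measured. It differs from compound 2 by methoxy in place of hydrogen on an aromatic carbon, which, read one bond further out, turns a 3,4-dimethoxyphenyl into a 3,4,5-trimethoxyphenyl. Going by the values given here, the only measured step that bears on this change is a 4.8-fold lower number from compound 1 to compound 2 (0.68 log units; beyond the scatter), the addition of a methoxy on the same phenyl, which was modest in size and beyond the scatter. Compound 3 adds a methoxy of the same kind, so a further drop in the number, of similar or somewhat smaller size, is expected rather than no change, though a single step is a thin basis for this. Compound 3 is therefore expected to show 4000 nM in this assay, within 1000 nM to 12000 nM, corresponding to the expected step of a 2.0-fold lower number from compound 2 to compound 3 (0.31 log units; beyond the scatter).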

Compound 3, half-maximal inhibitory concentration: 32400 nM
Compound 3: the middle estimate sits 8.1-fold (0.91 log units) below what was measured; the whole stated range lies below it.
By their numbers in this assay, from the lowest: compound 2; then compounds 3 and 1 (each within the scatter of the next).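

In this assay, a methoxy added to this phenyl does not always lower the number: a 4.8-fold lower number from compound 1 to compound 2 (0.68 log units; beyond the scatter) had suggested that direction, but the third methoxy, which turns the 3,4-dimethoxyphenyl into the 3,4,5-trimethoxyphenyl, reverses it, giving a 4.0-fold higher number from compound 2 to compound 3 (0.60 log units; beyond the scatter). The gain seen with the 3,4-dimethoxyphenyl is thus lost, and set against the 4-methoxyphenyl, the 3,4,5-trimethoxyphenyl shows a 1.2-fold lower number from compound 1 to compound 3 (0.08 log units; within the scatter), so compound 1 and compound 3 cannot be told apart, and of the three compounds only compound 2 stands clear of the other two. Nothing measured here speaks to why the same kind of change goes opposite ways on this ring.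

Going by these compounds, it remains open whether another group in the place of the third methoxy, such as a hydroxyl, a fluorine or an ethoxy, would keep the number of compound 2 or raise it as the methoxy does. On these data alone, it is also open whether the same reversal would hold with an amine or a carboxylic acid elsewhere on the phenyl, or with the fluorine on the far side of the amide replaced by chlorine.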